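The source may report more compounds than this note shows. Statements on the series, on what has been measured and on what is new or still open speak of the compounds shown alone.

Going by the values given here, in a functional assay on MGC-803 cells (Homo sapiens) for antiproliferative activity, read by MTT assay, with a stated time of 48 h (a lower number here means a stronger inhibitor, a higher number a weaker inhibitor), compound 1 (`COc1ccc(CN(C(=O)CSc2nc3ccccc3s2)c2cc(OC)c(OC)c(OC)c2)cc1N=[N+]=[N-]`) gives 187 nM, the highest of the three numbers so far and beyond the scatter from both others. Compound 2 (`COc1ccc2nc(SCC(=O)N(Cc3ccc(OC)c(O)c3)c3cc(OC)c(OC)c(OC)c3)sc2c1`) gives 71 nM, and compound 3 (`COc1ccc(CN(C(=O)CSc2nc3cc(Cl)ccc3s2)c2cc(OC)c(OC)c(OC)c2)cc1O`) gives 85 nM. Compound 4 (`COc1cc(N(Cc2ccccc2)C(=O)CSc2nc3ccccc3s2)cc(OC)c1OC`) simplifies compound 1, with phenyl in place of 3-azido-4-methoxyphenyl on a saturated chain carbon bound to an amide-type nitrogen. Among the compounds with values here, no measured step covers this change. The only one available, a 1.2-fold higher number from compound 2 to compound 3 (0.08 log units; within the scatter), swaps 6-methoxy-1,3-benzothiazol-2-yl for 5-chloro-1,3-benzothiazol-2-yl elsewhere in the molecule and stays within the scatter, so it offers little guidance. A weaker hint comes from compound 1 at 187 nM and compound 3 at 85 nM, whose numbers differ while their benzyl groups also differ, although these two compounds are not otherwise identical. The uncertain change towards a weaker inhibitor is expected and estimated as a 3.2-fold higher number from compound 1 to compound 4 (0.51 log units; beyond the scatter). For compound 4 the estimated value is 600 nM, with an expected range from 150 nM to 3000 nM.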

Compound 4, half-maximal inhibitory concentration: 44300 nM
Compound 4: the middle estimate sits 74-fold (1.87 log units) below what was measured, and the stated range ends below it.
By their numbers in this assay, from the lowest: compounds 2 and 3 (each within the scatter of the next); then compound 1; then compound 4.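

In this assay, going by these compounds alone, going from 3-azido-4-methoxybenzyl to benzyl gives a 240-fold higher number from compound 1 to compound 4 (2.37 log units; beyond the scatter), the first measured change at this position with the rest of the molecule held constant. The step shows that the position is highly sensitive: a bare phenyl on the saturated chain carbon bound to the amide-type nitrogen costs far more than the benzothiazole swap in a 1.2-fold higher number from compound 2 to compound 3 (0.08 log units; within the scatter), which stays within the scatter. Nothing available explains the size of this loss.

The step removes the azido and the methoxy together, leaving open which of the two matters more, or whether only their combination does. Also open, from the compounds shown here alone, is how a phenyl carrying only the methoxy, or an amine in place of the azido, would compare with compound 1 and compound 4.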